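The compounds below may be only part of what the source reports. "The series", "measured", "known", "first", "only" and "open" are said of these compounds alone.

Compound 1 `COc1cc(OC)c(C(=O)/C=C/c2ccccc2SC)c(OC)c1` gave 9900 nM in a functional assay on MDA-MB-231 cells (Homo sapiens) for cytotoxicity, with a stated time of 48 h; a lower number here means a stronger inhibitor, a higher number a weaker inhibitor. Compound 2 `COc1cccc(/C=C/C(=O)c2c(OC)cc(OC)cc2OC)c1` gave 8700 nM in this assay. Compound 3 `COc1cc(O)c(C(=O)/C=C/c2ccccc2SC)c(OC)c1` reached only a limit of this assay, > 20000 nM.

Compound 4 `COc1cccc(/C=C/C(=O)c2c(O)cc(OC)cc2OC)c1` has not yet been measured in this assay. Its core is that of compound 2, which differs from the core of compound 1 by 3-methoxyphenyl in place of 2-(methylsulfanyl)phenyl on a double-bonded chain carbon bound to a double-bonded chain carbon; this exchange of cores gave a 1.1-fold lower number from compound 1 to compound 2 (0.06 log units; within the scatter). Compound 1 and compound 2 therefore sit together and no order can be read between them.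

The change leading from compound 2 to compound 4 is hydrogen in place of methyl on an oxygen on an aromatic ring. The same change, (hydrogen in place of methyl on an oxygen on an aromatic ring), was made from compound 1 to compound 3, where it gave an at least 2.0-fold higher number from compound 1 to compound 3 (0.30 log units; that floor lies within the scatter). That step rests on (the limit of > 20000 nM in this assay, at which 1 of the 3 values shown sits), so its true size is not known beyond the floor stated.

Since the cores of compound 2 and compound 1 behave alike in this assay, and the change is the same in kind and in its surroundings, the step from compound 2 to compound 4 is expected to resemble the earlier one, and is estimated as a 2.3-fold higher number from compound 2 to compound 4 (0.36 log units; beyond the scatter). Compound 4 is accordingly expected to give around 20000 nM in this assay, most likely between 9000 nM and 50000 nM, with a real chance that the assay again reports only a limit rather than a number.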

Compound 4, half-maximal inhibitory concentration: 13200 nM
Beside the measured number, compound 4's estimate is 1.5-fold (0.18 log units) above it; the range from low to high includes it.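

In this assay, carried to a second core, the change from methoxy to hydroxy gave a 1.5-fold higher number from compound 2 to compound 4 (0.18 log units; within the scatter), so on this core the change is not shown to alter the read-out. Set beside the first case, this result does not establish that the step keeps its size from one core to another, nor that its size depends on the core: the same change on two cores in this assay, an at least 2.0-fold higher number (0.30 log units; that floor lies within the scatter) from compound 1 to compound 3 and a 1.5-fold higher number (0.18 log units; within the scatter) from compound 2 to compound 4; the limit leaves it open whether they differ. Going by these compounds alone, compound 3 gives > 20000 nM, which is a limit of the assay and not a number, so the step on the core of compound 1 is known only by its floor, and the series shows no measured pair of steps that could be compared in full: the limit of > 20000 nM in this assay, at which 1 of the 4 values shown sits.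

The compounds shown leave open how the read-out would respond if the hydrogen on this oxygen were replaced by something other than methyl, such as an ethyl group or a longer chain, or if an amine stood in place of the hydroxy. They also leave open whether the change would behave in the same way on a core carrying another group in place of 3-methoxyphenyl or 2-(methylsulfanyl)phenyl, such as a carboxylic acid.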